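Cyclohexyl to cyclopentyl on two related cores

The compounds below may be only part of what the source reports. "The series", "measured", "known", "first", "only" and "open" are said of these compounds alone.

Measured so far:
compound 1 `Cc1cnc(Nc2ccc(C#N)cc2)nc1NC1CCCCC1` gives 1300 nM
compound 2 `Cc1cnc(Nc2ccc(C#N)cc2)nc1NC1CCCC1` gives 170 nM
compound 3 `Cc1cc(NC2CCCCC2)nc(Nc2ccc(C#N)cc2)n1` gives 340 nM

All three numbers come from an ADME assay on MT4 cells (Homo sapiens) for cytotoxicity, read by MTT assay; a lower number here means that less compound is tolerated, a higher number that more compound is tolerated. Compound 1 and compound 2 share a core and differ in one place, (cyclopentyl in place of cyclohexyl on a nitrogen on an aromatic ring). That change produced a 7.6-fold lower number from compound 1 to compound 2 (0.88 log units; beyond the scatter), so the cyclopentyl compound is tolerated less well than its cyclohexyl partner.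

Compound 3 is built from the same atoms as compound 1, joined differently; the difference between the two cores is not broken down here. In this assay compound 3 sits closest to compound 2, within the scatter of it, and further from compound 1, beyond the scatter.

Compound 4 `Cc1cc(NC2CCCC2)nc(Nc2ccc(C#N)cc2)n1` is not yet measured. It stands to compound 3 as compound 2 stands to compound 1: cyclopentyl in place of cyclohexyl on a nitrogen on an aromatic ring. The place is described in the same words in both pairs, so this is the same change, made here on the core of compound 3. Going by the values given here, only one earlier instance exists, on a different core, so the transfer is uncertain. The step from compound 3 to compound 4 is expected to be a 4.9-fold lower number from compound 3 to compound 4 (0.69 log units; beyond the scatter), somewhat smaller than the earlier one, because a 7.6-fold lower number from compound 1 to compound 2 (0.88 log units; beyond the scatter) is a single observation and the two cores are arranged differently. Compound 4 is therefore estimated at 70 nM, with the expected range running from 25 nM to 200 nM.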

Compound 4, half-maximal cytotoxic concentration: 310 nM
The estimate for compound 4 lay 4.4-fold (0.65 log units) below the measured number; the whole stated range lies below it.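

In this assay, cyclopentyl in place of cyclohexyl on the core of compound 3 gives a 1.1-fold lower number from compound 3 to compound 4 (0.04 log units; within the scatter), so this pair cannot be told apart in this read-out. Set beside the earlier pair, the same change does not carry over in size from one core to the other: the same change on two cores in this assay, a 7.6-fold lower number (0.88 log units; beyond the scatter) from compound 1 to compound 2 and a 1.1-fold lower number (0.04 log units; within the scatter) from compound 3 to compound 4, 7.0-fold (0.84 log units) apart, beyond the scatter of two such steps This shows that, across these two pairs, the size of the step depends on the core, so a step read on one core is a poor guide to the other; it does not show what in the cores produces the gap, and two pairs cannot say how the change would read on a third core.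

The compounds shown leave open how a cyclobutyl ring or an open chain such as isopropyl on that nitrogen would read on each of the two cores. They also leave open whether the gap between the cores would persist with a carboxylic acid in place of the nitrile.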